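From 2,4-Dichlorophenyl to 2,3-Dichlorophenyl at the Ring Nitrogen

The source may report more compounds than this note shows. Statements on the series, on what has been measured and on what is new or still open speak of the compounds shown alone.

Measured so far:
compound 1 `CC(C)N1CCN(Cc2csc(N)c2C(=O)c2ccc(Cl)cc2)CC1`: -1%
compound 2 `Nc1scc(CN2CCN(c3ccc(Cl)cc3Cl)CC2)c1C(=O)c1ccc(Cl)cc1`: 2%

In a functional assay on CHO cells with adenosine receptor A1 (Homo sapiens) as the target, read by cAMP accumulation and immunoassay, with a stated time of 6 min, tested at 0.01 uM (a higher number here means a weaker effect of the compound at the concentration tested, a lower number a stronger effect), compound 2 stands highest of the two numbers, yet the step of a number 3 percentage points higher from compound 1 to compound 2 (within the scatter) lies within the scatter. Compound 3 `Nc1scc(CN2CCN(c3cccc(Cl)c3Cl)CC2)c1C(=O)c1ccc(Cl)cc1` differs from compound 2 by 2,3-dichlorophenyl in place of 2,4-dichlorophenyl on an amine nitrogen in a ring. Among the compounds with values here, the only measured step, a number 3 percentage points higher from compound 1 to compound 2 (within the scatter), also changed the group on that same ring nitrogen and left the read-out essentially unchanged, so no step beyond the scatter is expected for compound 3, that is no change at the digits printed from compound 2 to compound 3 (within the scatter). Compound 3 is therefore estimated at 2%, within a range from -10% to 14%.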

Compound 3, a percentage reported as activity, at one concentration (the size of the read-out at that concentration, not a potency): 1%
For compound 3 the middle estimate is 1 percentage points above the measured one, and the stated range covers the measured number.
By their numbers in this assay, from the lowest: compounds 1, 3 and 2 (each within the scatter of the next).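

In this assay, exchanging 2,4-dichlorophenyl for 2,3-dichlorophenyl, which has the same atoms joined differently, gives a number 1 percentage points lower from compound 2 to compound 3 (within the scatter), and exchanging isopropyl for 2,3-dichlorophenyl gives a number 2 percentage points higher from compound 1 to compound 3 (within the scatter). At this single concentration, the read-out therefore separates neither the two dichlorophenyl groups from each other nor 2,3-dichlorophenyl from isopropyl on this ring nitrogen. No measurement at hand offers an explanation for this result. The compounds shown leave open whether they would differ at another concentration. They also leave open whether a carboxylic acid on the phenyl ring, or a longer chain in place of isopropyl, would shift the read-out.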